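Pyrazole enones: halogen exchange on the aryl ketone

A few compounds are considered here, and "the series" means these few. Any claim that something is new, unique, unknown or untested is made for them only; others in the source may bear on it.

Measured so far:
compound 1 `COc1cc(-c2cc(/C=C/C(=O)c3ccc(Cl)c(Cl)c3)[nH]n2)cc(OC)c1OC`: 1260 nM
compound 2 `COc1ccc(-c2cc(/C=C/C(=O)c3ccc(N)cc3)[nH]n2)cc1OC`: 1880 nM
compound 3 `COc1cc(C(=O)/C=C/c2cc(-c3cc(OC)c(OC)c(OC)c3)n[nH]2)cc(OC)c1OC`: 1750 nM

All three compounds were run in a functional assay on COLO 205 cells (Homo sapiens) for inhibition, read by sulforhodamine B assay, with a stated time of 48 h; a higher number here means a weaker inhibitor of growth, a lower number a stronger inhibitor of growth. Compound 1 gives 1260 nM, the lowest of the three numbers, but compound 3 with 1750 nM and compound 2 with 1880 nM both lie within the scatter of it, so the three are not separated by these data. For the measured compounds named here, no pair among them differs in a single place, so no step can be drawn from the measured set.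

The next compound, compound 4 `COc1cc(-c2cc(/C=C/C(=O)c3ccc(F)c(F)c3)[nH]n2)cc(OC)c1OC`, differs from compound 1 in one place only: 3,4-difluorophenyl in place of 3,4-dichlorophenyl on a carbonyl carbon. Going by the values given here, the measured compounds give no step that bears directly on this exchange, so the expectation rests on the position of compound 1 alone. A step of modest size is expected, toward a somewhat higher number, and it may well fall inside the scatter. The expected step is a 1.7-fold higher number from compound 1 to compound 4 (0.24 log units; within the scatter) in this assay.

For compound 4 the estimate in this assay is 2200 nM, with a range from 900 nM to 5500 nM.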

Compound 4, concentration for 50% growth inhibition: 1690 nM
Compound 4: middle estimate off by 1.3-fold (0.11 log units), on the high side, within the range that was stated.
By their numbers in this assay, from the lowest: compounds 1, 4, 3 and 2 (each within the scatter of the next).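

In this assay, for the compounds shown here, the exchange of 3,4-dichlorophenyl for 3,4-difluorophenyl on a carbonyl carbon gives a 1.3-fold higher number from compound 1 to compound 4 (0.13 log units; within the scatter), the first step that isolates a single place, since no earlier pair differed in one place only. The step lies within the scatter, so this read-out does not separate the two groups, and at this position the exchange of both chlorine atoms for fluorine leaves the growth-inhibition number without a resolved change. No measured data bear on the reason for this result.

Both groups are dihalophenyl rings, so the step says nothing about how far this position tolerates other groups: a 3,4-dibromophenyl, an unsubstituted phenyl, or a phenyl carrying a nitrile or a carboxylic acid on the same carbonyl carbon could still move the number beyond the scatter. Going by these compounds, it also remains open whether a single chlorine or fluorine would behave like the pair, and whether the exchange stays this small in other cell lines.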